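Metabolic stability notes: from compound 3 to compound 4

The source may hold more compounds than are shown below. What is called first, only, known or untested is meant among the compounds shown, and "the series" means these compounds.

Measured compounds:
compound 1, `c1cnc(CN(CCCN2CCNCC2)[C@H]2CCCc3cccnc32)nc1`: 100%
compound 2, `c1cnc2c(c1)CCC[C@@H]2N(CCCN1CCNCC1)Cc1nc2ccccc2s1`: 50%
compound 3, `c1cnc2c(c1)CCC[C@@H]2N(CCCN1CCNCC1)Cc1cc2ccccc2cn1`: 66%

All three measured compounds share one core and differ only in the group on a saturated chain carbon bound to an amine nitrogen. In an ADME assay on microsomes from liver (Homo sapiens) for metabolic stability, read by LC-MS, with a stated time of 10 min, tested at 0.5 uM (a lower number here means that less of the compound is left, a higher number that more of the compound is left), compound 1 gives 100%, compound 2 gives 50% and compound 3 gives 66%. Compound 3 therefore stands second highest of the three numbers: a number 16 percentage points higher from compound 2 to compound 3 (beyond the scatter), while a number 34 percentage points lower from compound 1 to compound 3 (beyond the scatter).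

Compound 4, `c1cnc2c(c1)CN[C@@H](CN(CCCN1CCNCC1)[C@H]1CCCc3cccnc31)C2`, is not yet measured. Relative to compound 3 the change is a group of 10 heavy atoms (8 carbon, 2 nitrogen; one six-membered non-aromatic ring with 1 hetero atom, one six-membered aromatic ring with 1 hetero atom) in place of a group of 10 heavy atoms (9 carbon, 1 nitrogen; one six-membered aromatic ring of carbon only, one six-membered aromatic ring with 1 hetero atom), on a saturated chain carbon bound to an amine nitrogen.

For the measured compounds named here, the steps that bear on this place are a number 50 percentage points lower from compound 1 to compound 2 (beyond the scatter), a number 34 percentage points lower from compound 1 to compound 3 (beyond the scatter) and a number 16 percentage points higher from compound 2 to compound 3 (beyond the scatter). Both steps away from pyrimidin-2-yl towards a bicyclic aromatic group were large losses; the step between the two bicyclic aromatic groups was modest. None of them tests the entering group, which is counted as one six-membered non-aromatic ring with one hetero atom and one six-membered aromatic ring with one hetero atom, so the direction is uncertain. A modest rise from compound 3 is expected, a number 10 percentage points higher from compound 3 to compound 4 (within the scatter), staying below compound 1 because of 100%. For compound 4 the estimated value is 76%, with a range from 55% to 95%.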

Compound 4, percent of the compound remaining: 79%
Compound 4: middle estimate off by 3 percentage points, on the low side; the range from low to high includes it.
By their numbers in this assay, from the lowest: compound 2; then compound 3; then compound 4; then compound 1.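

For the compounds shown here, the first group at this place, on a saturated chain carbon bound to an amine nitrogen, to carry a six-membered non-aromatic ring with 1 hetero atom stands above both bicyclic aromatic groups in this assay: a number 13 percentage points higher from compound 3 to compound 4 (beyond the scatter) and a number 29 percentage points higher from compound 2 to compound 4 (beyond the scatter). The leaving isoquinolin-3-yl and the entering group count the same heavy atoms, so in this pair the number moves with no change in group size, only with a different ring make-up and an added hydrogen-bond donor. Pyrimidin-2-yl remains the highest of the four groups, a number 21 percentage points lower from compound 1 to compound 4 (beyond the scatter), so the entering group narrows the loss seen with the bicyclic aromatic groups but does not close it.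

Ring saturation, the extra ring nitrogen and the hydrogen-bond donor all change together in this one step, so which of them goes with the higher number stays open, and no measurement at hand gives a cause for it. Also open, from the compounds shown here alone, is how the number would move with a single-ring piperidin-2-yl or pyridin-2-yl at this place, or with the opposite configuration at the defined stereocentre of the entering group.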